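This account rests on a few compounds, and the source may have more. Where it says the series, first, only, none or still open, it means among the compounds named here.

Of the compounds shown here, three that share one core have been measured so far. Compound 1 `NC(=O)c1cn(Cc2nnc(-c3cc(S(N)(=O)=O)c(SCc4ccccc4)cc3Cl)o2)nn1` gives 72000 nM in a functional assay on HCT-116 cells (Homo sapiens) for cytotoxicity, read by MTT assay, with a stated time of 72 h; a higher number here means a weaker inhibitor, a lower number a stronger inhibitor. Compound 2 `CC(C)(O)c1cn(Cc2nnc(-c3cc(S(N)(=O)=O)c(SCc4ccccc4)cc3Cl)o2)nn1` gives 82000 nM in this assay, and the change a 1.1-fold higher number from compound 1 to compound 2 (0.06 log units; within the scatter) stays within the scatter. Compound 3 `NS(=O)(=O)c1cc(-c2nnc(/C=C/c3ccccc3)o2)c(Cl)cc1SCc1ccccc1` gives 18000 nM in this assay, the lowest of the three numbers: the step of a 4.0-fold lower number from compound 1 to compound 3 (0.60 log units; beyond the scatter) and the step of a 4.6-fold lower number from compound 2 to compound 3 (0.66 log units; beyond the scatter) both lie beyond the scatter, so compound 3 stands as the strongest inhibitor among the measured compounds.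

Compound 4 `NS(=O)(=O)c1cc(-c2nnc(/C=C/c3c(Cl)cccc3Cl)o2)c(Cl)cc1SCc1ccccc1` has not yet been measured. It differs from compound 3 in one place: 2,6-dichlorophenyl in place of phenyl on a double-bonded chain carbon bound to a double-bonded chain carbon. Among the compounds with values here, both steps measured so far swap a whole side chain for the 2-phenylethenyl group; no measured step varies the phenyl of that group once it is in place, so none of them speaks directly to the change from compound 3 to compound 4. What the data show is that the 2-phenylethenyl side chain carries the lowest number seen, and compound 4 keeps that chain with two chlorines added to its ring.

Within the data shown here, with no step that bears on this change, compound 4 is estimated to stay close to compound 3 in this assay, at 15000 nM, between 5000 nM and 45000 nM, which would mean an expected step of a 1.2-fold lower number from compound 3 to compound 4 (0.08 log units; within the scatter).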

Compound 4, half-maximal inhibitory concentration: 32000 nM
Beside the measured number, compound 4's estimate is 2.1-fold (0.33 log units) below it, and the stated range covers the measured number.
By their numbers in this assay, from the lowest: compounds 3 and 4 (each within the scatter of the next); then compounds 1 and 2 (each within the scatter of the next).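

In this assay, within the data shown here, the ring of the 2-phenylethenyl group is varied here for the first time, and a 1.8-fold higher number from compound 3 to compound 4 (0.25 log units; within the scatter) stays within the scatter, so 2,6-dichlorophenyl in place of phenyl on a double-bonded chain carbon bound to a double-bonded chain carbon leaves the number indistinguishable from that of compound 3. The two side chains carrying a 1H-1,2,3-triazol-1-yl methyl group still give higher numbers with the new ring in place: a 2.6-fold lower number from compound 2 to compound 4 (0.41 log units; beyond the scatter) and a 2.3-fold lower number from compound 1 to compound 4 (0.35 log units; beyond the scatter) both lie beyond the scatter, and both are modest steps. No measurement in hand accounts for these numbers.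

On these data alone, both chlorines enter together, so the effect of a single chlorine on this ring remains open, as does whether a methoxy group or an amine on the ring would give a step beyond the scatter. All four compounds also keep the benzylsulfanyl group and the sulfonamide of the shared core, which leaves open how the numbers would respond if either were replaced, for example by a carboxylic acid in place of the sulfonamide.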